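Swapping a ring amine for a chain amine

The compounds below may be only part of what the source reports. "The series", "measured", "known", "first", "only" and "open" are said of these compounds alone.

Compound 1 `CN1CCN(CCCOc2ccc3c(c2)N(Cc2ccccc2)C(=O)CC3)CC1` is the reference point in this set. In an assay on cell membranes (strain Dunkin Hartley) for displacement of a labelled ligand from Sigma non-opioid intracellular receptor 1 (Cavia porcellus), read by scintillation counting, with a stated time of 180 min (on this read-out higher numbers stand for weaker inhibition and lower numbers for stronger inhibition), compound 1 gives 4.3 nM, the lowest number among the three measured compounds. Compound 2 `O=C1CCc2ccc(OCCCN3CCN(c4ccccc4)CC3)cc2N1Cc1ccccc1` gives 341 nM in this assay, and compound 3 `CN(C)CCCOc1ccc2c(c1)N(Cc1ccccc1)C(=O)CC2` gives 83.2 nM. Both measured steps away from compound 1 led to weaker binding: a 79-fold higher number from compound 1 to compound 2 (1.90 log units; beyond the scatter) and a 19-fold higher number from compound 1 to compound 3 (1.29 log units; beyond the scatter).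

Compound 4 `CCN(CC)CCCOc1ccc2c(c1)N(Cc1ccccc1)C(=O)CC2` has not yet been measured. It differs from compound 1 by the change (diethylamino in place of 4-methylpiperazin-1-yl on a saturated chain carbon, three bonds along the chain from an oxygen on an aromatic ring). Among the compounds with values here, of the measured steps, the one that bears most directly on this change is the one to compound 3, where a chain amine, dimethylamino, also replaced the 4-methylpiperazin-1-yl group at the same place, and the number rose well beyond the scatter. Diethylamino is another chain amine at that position, so a rise of similar kind is expected, though with less certainty about its size. Compound 4 is therefore expected to bind more weakly than compound 1, with a step of about a 10-fold higher number from compound 1 to compound 4 (1.02 log units; beyond the scatter) in this assay. The estimate for compound 4 is 45 nM, with a plausible range from 10 nM to 200 nM.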

Compound 4, inhibition constant: 39.4 nM
Compound 4: middle estimate off by 1.1-fold (0.06 log units), on the high side; low and high end bracket the measured number.
By their numbers in this assay, from the lowest: compound 1; then compound 4; then compound 3; then compound 2.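

In this assay, the step of a 9.2-fold higher number from compound 1 to compound 4 (0.96 log units; beyond the scatter) shows that the loss of binding seen with dimethylamino is not unique to that group: diethylamino, a second open-chain amine on the same saturated chain carbon, also gives a weaker result than the 4-methylpiperazin-1-yl ring. The choice among open-chain amines still has an effect, as the step of a 2.1-fold lower number from compound 3 to compound 4 (0.32 log units; beyond the scatter) is small but printed as beyond the scatter, so the ethyl groups recover part of the loss without reaching the low number of compound 1. Nothing measured here gives a reason for either step.

The compounds shown leave open whether the low number depends on the second ring nitrogen and its methyl group, which other ring amines such as piperidin-1-yl or morpholin-4-yl could test. They also leave open whether the trend from dimethylamino to diethylamino would continue with a larger open-chain amine such as dipropylamino, or whether a longer chain between the oxygen and the amine would change these steps.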